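Replacing the nitrogen substituent of compound 1

The compounds below may be only part of what the source reports. "The series", "measured", "known", "first", "only" and "open" are said of these compounds alone.

Compound 1 `O=C(Nc1ccc(O)c2c(=O)cc(-c3ccccc3Cl)oc12)c1ccc(Cl)cc1` gives 4600 nM
Compound 2 `O=C(Nc1c(O)cc(O)c2c(=O)cc(-c3ccccc3Cl)oc12)c1ccc(Cl)cc1` gives 13000 nM
Compound 3 `O=c1cc(-c2ccccc2Cl)oc2c(NS(=O)(=O)c3ccccc3)ccc(O)c12` is not yet measured

For the measured compounds named here, in a functional assay on MCF7 cells (Homo sapiens) for antiproliferative activity (on this read-out lower numbers stand for stronger inhibition and higher numbers for weaker inhibition), compound 1 gives 4600 nM and holds the lower of the two numbers so far, with compound 2 at 13000 nM as its nearest neighbour. Going by the values given here, compound 3 keeps the rest of compound 1 but carries phenylsulfonyl in place of (4-chlorophenyl)carbonyl on a nitrogen on an aromatic ring as its single change. Among the compounds with values here, no measured step touches this nitrogen substituent, so the data give no firm direction. Within the data shown here, the only measured step is a 2.8-fold higher number from compound 1 to compound 2 (0.45 log units; beyond the scatter) for hydroxy in place of hydrogen on an aromatic carbon, which is a different change and serves only as a rough gauge of size. A step no larger than that one is therefore expected, leaning weakly towards a higher number. The expected change is a 1.4-fold higher number from compound 1 to compound 3 (0.15 log units; within the scatter) in this assay on this estimate. Compound 3 is thus estimated at 6500 nM with 2000 nM to 20000 nM as the expected range.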

Compound 3, half-maximal inhibitory concentration: 16000 nM
Compound 3: the middle estimate sits 2.5-fold (0.39 log units) below what was measured; the measured number falls inside the stated range.
By their numbers in this assay, from the lowest: compound 1; then compounds 2 and 3 (each within the scatter of the next).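

In this assay, the nitrogen substituent now has a measured step of its own: phenylsulfonyl in place of (4-chlorophenyl)carbonyl gives a 3.5-fold higher number from compound 1 to compound 3 (0.54 log units; beyond the scatter), showing that this place on the shared core responds to what the nitrogen carries and that this exchange weakens inhibition. The step comes without a change in heavy-atom count, as both groups have 9 heavy atoms and one six-membered aromatic ring of carbon only, so these counts alone do not account for the difference between compound 1 and compound 3. No measurement available here gives a reason for the step.

The exchange replaces the carbonyl with a sulfonyl and also removes the chlorine, so the compounds shown cannot say which of the two accompanies the weaker inhibition; 4-chlorophenylsulfonyl or an unsubstituted benzoyl group on the same nitrogen would separate them. As far as these compounds go, how this place responds to a group without an aromatic ring, such as acetyl or a free amine, also remains open.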